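A methoxyphenyl swap at the assay limit

The compounds below may be only part of what the source reports. "The series", "measured", "known", "first", "only" and "open" are said of these compounds alone.

Within the data shown here, in an ADME assay on cells (Lymphocyte, Homo sapiens) for cytotoxicity, read by MTT assay, with a stated time of 48 h (on this read-out lower numbers stand for stronger inhibition and higher numbers for weaker inhibition), compound 1 `COC(=O)/C(=C\c1ccc(O)cc1)Sc1ccnc2cc(Cl)ccc12` gives 33700 nM as the one true number in the set. Compound 2 `COC(=O)/C(=C\c1ccc(OC(=O)c2ccccc2)cc1)Sc1ccnc2cc(Cl)ccc12` reads > 100000 nM as a limit of the assay. Compound 3 `COC(=O)/C(=C\c1ccc(OC(=O)c2cccc(OC)c2)cc1)Sc1ccnc2cc(Cl)ccc12` reads > 100000 nM in this assay, which is also a limit and not a number. Compound 3 therefore stands at the limit of > 100000 nM in this assay, at which 2 of the 3 values shown sit, and has no exact value.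

Compound 4 `COC(=O)/C(=C\c1ccc(OC(=O)c2ccccc2OC)cc1)Sc1ccnc2cc(Cl)ccc12` differs by 2-methoxyphenyl in place of 3-methoxyphenyl on a carbonyl carbon and keeps the rest of compound 3. Two measured steps show acylation of the oxygen on the aromatic ring weakening the read-out: an at least 2.9-fold higher number from compound 1 to compound 2 (0.47 log units; beyond the scatter) and an at least 2.9-fold higher number from compound 1 to compound 3 (0.47 log units; beyond the scatter). Both are beyond the scatter and both are lower bounds. The closest comparison, a change on the same benzoyl ring, is a step that the two limits leave unreadable from compound 2 to compound 3 and gives no size. Compound 4 keeps the acylated oxygen of compound 3, so another limit reading seems likely. Nothing measured points to a shift in either direction, so a number no higher from compound 3 to compound 4 (the limit leaves the size open) is the expected step, with no size beyond the scatter anticipated. Compound 4 is estimated at 100000 nM in this assay with an expected range from 40000 nM to 250000 nM as its span.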

Compound 4, half-maximal inhibitory concentration: > 100000 nM
Compound 4 gave a limit, no number; the forecaster's own chance of this, stated with the estimate: 75%; the middle value sits exactly at the limit.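

Placing the methoxy as 2-methoxyphenyl rather than 3-methoxyphenyl on the carbonyl carbon does not bring the reading in this assay off the limit, and compound 4 reads > 100000 nM, which is a limit and not a number. Acylation of the oxygen now holds with a third benzoyl-type group, with an at least 2.9-fold higher number from compound 1 to compound 4 (0.47 log units; beyond the scatter), and this too is a lower bound. The steps among the three acylated compounds cannot be read, so these compounds share one reading without a measured order, and the position now has a third entry at the same reading: the limit of > 100000 nM in this assay, at which 3 of the 4 values shown sit.

On these data alone, how far apart the three acylated compounds truly lie remains open. So does whether an amine or a carboxylic acid on the benzoyl ring, or a longer chain in place of that ring, would give a reading under the limit.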